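This account rests on a few compounds, and the source may have more. Where it says the series, first, only, none or still open, it means among the compounds named here.

Measured in a functional assay on MCF7 cells (Homo sapiens) for antiproliferative activity, read by MTT assay, with a stated time of 96 h; on this read-out lower numbers stand for stronger inhibition and higher numbers for weaker inhibition:
- compound 1 `S=C(N/N=C1\CC2(CCCCC2)Oc2c1ccc1ccccc21)N1CCOCC1`: 11900 nM
- compound 2 `S=C(CN1CCCCC1)N/N=C1\CC2(CCCCC2)Oc2c1ccc1ccccc21`: 11700 nM

Compound 2 has no separate place on these numbers. For the measured compounds named here, the one measured step, a 1.0-fold lower number from compound 1 to compound 2 (0.01 log units; within the scatter), leaves it level with compound 1. That step exchanged morpholin-4-yl for (piperidin-1-yl)methyl on a thiocarbonyl carbon, and the thiocarbonyl itself stayed in place.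

The move to compound 3 `N/N=C1\CC2(CCCCC2)Oc2c1ccc1ccccc21` goes further, with the change (a hydrogen atom in place of a group of 9 heavy atoms (7 carbon, 1 nitrogen, 1 sulfur; one six-membered non-aromatic ring with 1 hetero atom), on an amine nitrogen). The whole group is gone, sulfur and six-membered non-aromatic ring included, and the amine nitrogen is left bearing hydrogen. Going by the values given here, no measured compound lacks this group, so the single step bears on the question only indirectly. It shows that one exchange on the thiocarbonyl carbon moved nothing beyond the scatter, but it does not show what loss of the whole group does.

A modest move towards a higher number is therefore expected from the level of compound 2 at 11700 nM, with much uncertainty. The expected change is a 1.5-fold higher number from compound 2 to compound 3 (0.19 log units; within the scatter). For compound 3 the estimate is 18000 nM, with an expected range from 6000 nM to 50000 nM.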

Compound 3, half-maximal inhibitory concentration: 9740 nM
Estimate against measurement, compound 3: 1.8-fold (0.27 log units) above; low and high end bracket the measured number.
By their numbers in this assay, from the lowest: compounds 3, 2 and 1 (each within the scatter of the next).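

In this assay, the change on the amine nitrogen gives a 1.2-fold lower number from compound 2 to compound 3 (0.08 log units; within the scatter), so stripping the whole group, with its sulfur and its six-membered non-aromatic ring, leaves the number level. The same holds for the morpholine-bearing group, with a 1.2-fold lower number from compound 1 to compound 3 (0.09 log units; within the scatter), which means that all three compounds now stand level and that the amine nitrogen bearing only hydrogen does as well as either substituted form. The earlier pair showed only that one group could stand in for another on the thiocarbonyl carbon, whereas these steps show that, among the compounds shown, neither group is needed for the activity seen in this assay, and nothing at hand gives a reason for this.

From the compounds shown here alone, what remains open is whether any group on this amine nitrogen can move the number beyond the scatter in either direction, for instance an acetyl group, a carboxylic acid or a longer alkyl chain. Since the three compounds share the same core and differ only here, they also leave open how much of the activity rests on that core, which a change to the cyclohexane ring or to the ring oxygen could begin to address.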